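Methyl in Place of Chloro on the Shared Core

The compounds below may be only part of what the source reports. "The series", "measured", "known", "first", "only" and "open" are said of these compounds alone.

Of the compounds shown here, three built on one shared core have been measured in a functional assay on HEK293 cells for agonist activity at Neuronal acetylcholine receptor; alpha4/beta2 (Homo sapiens), read by FLIPR; a higher number here means that more compound is needed for the effect, a lower number that less compound is needed. Compound 1 `Clc1ccc(N2CC[C@H]3CN[C@H]3C2)cn1` gives 13 nM. Compound 2 `Clc1cc(N2CC[C@H]3CN[C@H]3C2)cnc1Cl` gives 12 nM, the lowest of the three numbers, and the step of a 1.1-fold lower number from compound 1 to compound 2 (0.03 log units; within the scatter) keeps it within the scatter of compound 1. Compound 3 `Clc1cc(N2CC[C@@H]3CN[C@@H]3C2)cnc1Cl` gives 82 nM; the step of a 6.8-fold higher number from compound 2 to compound 3 (0.83 log units; beyond the scatter) lies beyond the scatter, and the fact that compounds 2 and 3 differ only in the configuration as drawn is all that separates the two.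

The unmeasured compound 4 `Cc1cc(N2CC[C@H]3CN[C@H]3C2)cnc1Cl` differs from compound 2 by methyl in place of chloro on an aromatic carbon. Of the measured steps, only a 1.1-fold lower number from compound 1 to compound 2 (0.03 log units; within the scatter) concerns the same place on the core: putting a chloro there left the number essentially unchanged. The mirror-image step a 6.8-fold higher number from compound 2 to compound 3 (0.83 log units; beyond the scatter) concerns configuration alone and offers no guidance for this exchange. A methyl in place of that chloro is therefore expected to move the number little, if at all, in this assay, with the step of no change at the digits printed from compound 2 to compound 4 (within the scatter) expected to remain inside the scatter and without a clear direction. Compound 4 is estimated at 12 nM, within a range from 5 nM to 35 nM.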

Compound 4, half-maximal effective concentration: 7.2 nM
Beside the measured number, compound 4's estimate is 1.7-fold (0.22 log units) above it, within the range that was stated.
By their numbers in this assay, from the lowest: compounds 4, 2 and 1 (each within the scatter of the next); then compound 3.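

Among these compounds, at the aromatic carbon ortho to a chloro group, the methyl of compound 4 is the first group measured here that carries no halogen, yet a 1.7-fold lower number from compound 2 to compound 4 (0.22 log units; within the scatter) shows that in this assay it cannot be told apart from the chloro of compound 2. Set against hydrogen, methyl gives a 1.8-fold lower number from compound 1 to compound 4 (0.26 log units; within the scatter), and chloro gives a 1.1-fold lower number from compound 1 to compound 2 (0.03 log units; within the scatter), so hydrogen, chloro and methyl at this position all stand within the scatter of one another, and none of the three can be ranked above the others in this assay. Among the compounds shown here, the only evidence at hand concerns configuration and does not bear on this exchange, so the compounds offer no account of why these groups read alike.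

From the compounds shown here alone, whether this tolerance reaches beyond these small groups stays open, since an amine, a carboxylic acid or a longer chain at this carbon could give a quite different number. For the compounds shown here, also open is whether the mirror image of compound 4 would show a gap like a 6.8-fold higher number from compound 2 to compound 3 (0.83 log units; beyond the scatter), which so far rests on the single pair of compounds 2 and 3.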